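Chain shortening on the nitrogen substituent of a trimethoxybenzyl purine

The compounds below may be only part of what the source reports. "The series", "measured", "known", "first", "only" and "open" are said of these compounds alone.

Measured compounds:
Compound 1, `COc1cc(Cc2nc3c(N)nc(F)nc3n2CC2CCCO2)cc(OC)c1OC`: 22900 nM
Compound 2, `CCCCCn1c(Cc2cc(OC)c(OC)c(OC)c2)nc2c(N)ncnc21`: 61700 nM
Compound 3, `CCCCn1c(Cc2cc(OC)c(OC)c(OC)c2Br)nc2c(N)ncnc21`: 25100 nM

All three compounds share a core and a trimethoxybenzyl group and were tested in a functional assay on MCF7 cells (Homo sapiens) for antiproliferative activity; a higher number here means a weaker inhibitor, a lower number a stronger inhibitor. Compound 2 stands at the highest number of the three. Compound 3 comes nearest, with a number a good deal lower, and compound 1 lies furthest, lower again; both gaps from compound 2 exceed the usual scatter. Compound 4, `C=CCCn1c(Cc2cc(OC)c(OC)c(OC)c2)nc2c(N)ncnc21`, has not been measured yet. It differs from compound 2 in one place: vinyl in place of propyl on a saturated chain carbon, two bonds along the chain from an aromatic nitrogen. Among the compounds with values here, no pair of measured compounds differs in a single place, so no measured step guides this change. The three compounds all sit at weak inhibition, and a modest change of the chain on the nitrogen is expected to move the number little. Compound 4 is therefore expected to lie in this assay at 45000 nM, with a range from 15000 nM to 130000 nM. The estimated step of a 1.4-fold lower number from compound 2 to compound 4 (0.14 log units; within the scatter) is expected to be small, toward a somewhat lower number, within or close to the scatter.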

Compound 4, half-maximal inhibitory concentration: 40700 nM
Compound 4: middle estimate off by 1.1-fold (0.04 log units), on the high side; the measured number falls inside the stated range.
By their numbers in this assay, from the lowest: compounds 1, 3, 4 and 2 (each within the scatter of the next, the first and the last beyond it).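

In this assay, within the data shown here, this is the first comparison that changes only one place, and it reads a 1.5-fold lower number from compound 2 to compound 4 (0.18 log units; within the scatter). Exchanging propyl for vinyl on a saturated chain carbon, two bonds along the chain from an aromatic nitrogen, removes one heavy atom and adds a double bond outside aromatic rings, yet the step stays within the scatter. This position therefore accepts the change from pentyl to but-3-en-1-yl on the nitrogen without a readable shift in the number, at least for this pair.

Going by these compounds, whether an amine, a carboxylic acid or a longer chain at this place would give a step beyond the scatter remains open. No independent measurement bears on this result.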